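The source may hold more compounds than are shown below. What is called first, only, known or untested is meant among the compounds shown, and "the series" means these compounds.

Measured in a functional assay on HEK293 cells for activation of melanin-concentrating hormone receptor 1 (Homo sapiens), read by inositol phosphate accumulation; a higher number here means that more compound is needed for the effect, a lower number that less compound is needed:
- compound 1 `CCCc1cc(N)c2cc(NC(=O)/C=C/c3ccc(C(C)(C)C)cc3)ccc2n1`: 910 nM
- compound 2 `Nc1cc(C2CCCC2)nc2ccc(NC(=O)/C=C/c3ccc(C(F)(F)F)cc3)cc12`: 68 nM
- compound 3 `CCCc1cc(NC2CCC2)c2cc(NC(=O)/C=C/c3ccc(C(F)(F)F)cc3)ccc2n1`: 270 nM

Compound 3 holds the second highest of the three numbers in this assay. Its nearest neighbour is compound 1, whose number is higher by a margin beyond the usual scatter; furthest from it is compound 2, whose number is lower by a margin that also lies beyond the scatter. For the measured compounds named here, the three compounds differ from one another in more than one place, so no single step between them can be isolated, and the values show only the overall spread.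

Compound 4 `CCCc1cc(N2CCCC2)c2cc(NC(=O)/C=C/c3ccc(C(F)(F)F)cc3)ccc2n1` is not yet measured. It differs from compound 3 in one place: pyrrolidin-1-yl in place of cyclobutylamino on an aromatic carbon. The two compounds share every atom, and only the way the five heavy atoms of the side group are joined to the core changes; the hydrogen-bond donor of the cyclobutylamino group is no longer present in the pyrrolidin-1-yl group.

Going by the values given here, no measured pair shows this change, so the expectation rests on the spread of the series alone. A small step is expected, from compound 3 to compound 4 of a 1.5-fold higher number from compound 3 to compound 4 (0.17 log units; within the scatter), most likely toward a somewhat higher number but not clearly beyond the scatter. Compound 4 is estimated at 400 nM in this assay, with a range of 110 nM to 1500 nM.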

Compound 4, half-maximal effective concentration: 2800 nM
Compound 4: middle estimate off by 7.0-fold (0.85 log units), on the low side; the measured number lies above the stated range.
By their numbers in this assay, from the lowest: compound 2; then compound 3; then compound 1; then compound 4.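

In this assay, for the compounds shown here, the position opposite the ring nitrogen proves sensitive to how its side group is joined: a 10-fold higher number from compound 3 to compound 4 (1.02 log units; beyond the scatter) is the first step that can be read at a single place, and the same atoms, joined differently, are enough to carry the number well beyond the scatter. Two things change together in this step, since the hydrogen-bond donor of cyclobutylamino is lost and the four-membered ring of carbon only gives way to a five-membered ring holding the nitrogen, and one pair cannot separate them. Nothing at hand gives a measured reason for the size of the step.

Going by these compounds, whether the donor or the ring carries the step remains open, and cyclopentylamino, which keeps the donor, and dimethylamino, which has neither donor nor ring, on the same aromatic carbon would bear on it. Also open, on these data alone, is whether the step would look the same for piperidin-1-yl or morpholin-4-yl, or with a chain other than the propyl group on the shared core.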